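The source may report more compounds than this note shows. Statements on the series, on what has been measured and on what is new or still open speak of the compounds shown alone.

Three aryl selenium compounds sharing a carbamate-substituted phenyl unit have been tested in a functional assay on PC-3 cells (Homo sapiens) for cytotoxicity, read by MTT assay, with a stated time of 72 h; on this read-out lower numbers stand for stronger inhibition of growth and higher numbers for weaker inhibition of growth. Compound 1, `COc1ccc(OC(=O)Nc2ccc([Se]C#N)cc2)cc1`, carries a methoxyphenyl carbamate and a selenocyanate group; in this assay compound 1 gives 44600 nM. Compound 2, `CC(C)COC(=O)Nc1ccc([Se][Se]c2ccc(NC(=O)OCC(C)C)cc2)cc1`, is a diselenide bridging two isobutyl carbamate phenyl units, and in this assay compound 2 gives 48900 nM. Compound 3, `CCCOC(=O)Nc1ccc([Se]C#N)cc1`, pairs a propyl carbamate with the selenocyanate group, and in this assay compound 3 gives 47400 nM. Its number falls between those of compound 1 and compound 2, yet all three lie within the usual scatter of one another, so no ordering among them can be read from these data.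

Compound 4, `CCCCOC(=O)Nc1ccc([Se]C#N)cc1`, has not yet been measured. It differs from compound 3 by one change, (methyl in place of hydrogen on a saturated chain carbon, three bonds along the chain from an oxygen next to a carbonyl group), that is, methyl in place of hydrogen on a saturated chain carbon, three bonds along the chain from an oxygen next to a carbonyl group; read one bond further out, propyl becomes butyl. Since the three measured compounds, with quite different carbamate esters and selenium groups, all sit at essentially one level, the expectation is that the step from compound 3 to compound 4 stays within the scatter, with no direction favoured: a 1.0-fold lower number from compound 3 to compound 4 (0.01 log units; within the scatter). Compound 4 is therefore estimated at 46000 nM, with a range from 25000 nM to 85000 nM.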

Compound 4, concentration for total growth inhibition: 40800 nM
For compound 4 the middle estimate is 1.1-fold (0.05 log units) above the measured one; measured number inside the range.
By their numbers in this assay, from the lowest: compounds 4, 1, 3 and 2 (each within the scatter of the next).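

In this assay, among these compounds, the pair of compound 3 and compound 4 gives the first direct reading at a single place, and the propyl to butyl difference amounts to a 1.2-fold lower number from compound 3 to compound 4 (0.07 log units; within the scatter). Methyl in place of hydrogen on a saturated chain carbon, three bonds along the chain from an oxygen next to a carbonyl group, therefore does not separate these two selenocyanate carbamates, which the earlier compounds, differing from one another in more than one place, could not show directly. No measurement on hand bears on why this step has the size it has.

The compounds shown rest on this single step, so they leave open whether the same holds for a longer chain such as hexyl or octyl, or whether the read-out would move beyond the scatter with a polar end group on the chain, such as an amine or a carboxylic acid. They also leave open whether methyl at this place would have a similar outcome on the diselenide form or with a different group in place of the selenocyanate, such as a thiocyanate.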